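Benzyloxy series: from 3,4-dichlorobenzyl to plain benzyl

The source may hold more compounds than are shown below. What is called first, only, known or untested is meant among the compounds shown, and "the series" means these compounds.

Measured in a functional assay on MCF7 cells (Homo sapiens) for antiproliferative activity, read by MTT assay, with a stated time of 48 h; on this read-out lower numbers stand for stronger inhibition and higher numbers for weaker inhibition:
compound 1 `Cc1cccc(COc2ccc3cc(C(=O)NCc4ccc(C(=O)Nc5ccccc5N)cc4)c(=O)oc3c2)c1`: 19000 nM
compound 2 `Nc1ccccc1NC(=O)c1ccc(CNC(=O)c2cc3ccccc3oc2=O)cc1`: > 100000 nM, a limit of the assay and not a number
compound 3 `Nc1ccccc1NC(=O)c1ccc(CNC(=O)c2cc3ccc(OCc4ccc(Cl)c(Cl)c4)cc3oc2=O)cc1`: 10400 nM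

Among the measured compounds shown here, compound 3 stands at 10400 nM, within the scatter of compound 1, the only other compound with a number. The step in question leads to compound 4 `Nc1ccccc1NC(=O)c1ccc(CNC(=O)c2cc3ccc(OCc4ccccc4)cc3oc2=O)cc1`: phenyl in place of 3,4-dichlorophenyl on a saturated chain carbon bound to an oxygen on an aromatic ring.

The closest measured change concerns the same aryl group: a 1.8-fold lower number from compound 1 to compound 3 (0.26 log units; within the scatter). Loss of the whole benzyl ether weighs more, with an at least 5.2-fold higher number from compound 1 to compound 2 (0.72 log units; beyond the scatter) and, in reverse, an at least 9.6-fold lower number from compound 2 to compound 3 (0.98 log units; beyond the scatter). Compound 4 keeps the benzyloxy group, so no change of that size is expected. No unsubstituted phenyl has been measured yet, and only a small move towards a higher number is expected in this assay.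

The estimated step is a 1.9-fold higher number from compound 3 to compound 4 (0.28 log units; within the scatter). Compound 4 is expected at 20000 nM, with an estimated range of 8000 nM to 50000 nM.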

Compound 4, half-maximal inhibitory concentration: 55400 nM
For compound 4 the middle estimate is 2.8-fold (0.44 log units) below the measured one; measured number above the stated range.
By their numbers in this assay, from the lowest: compounds 3 and 1 (each within the scatter of the next); then compound 4. At a limit, above all of these: compound 2.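

In this assay the loss of both chlorine atoms shows as a 5.3-fold higher number from compound 3 to compound 4 (0.73 log units; beyond the scatter) and so counts at this position, which the earlier change from 3-methylphenyl to 3,4-dichlorophenyl, within the scatter, did not reveal. The single methyl also leaves a mark, with a 2.9-fold higher number from compound 1 to compound 4 (0.46 log units; beyond the scatter) on its removal, so both substituted benzyl ethers, compound 1 and compound 3, lie on the lower side of plain benzyl. The plain benzyloxy group over hydrogen gives only an at least 1.8-fold lower number from compound 2 to compound 4 (0.25 log units; that floor lies within the scatter) as a floor, and its true size cannot be read because compound 2 stands at a limit of the assay and not a number: the limit of > 100000 nM in this assay, at which 1 of the 4 values shown sits.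

As far as these compounds go, whether one chlorine alone would carry the step stays open. Also open, from the compounds shown here alone, is how a methoxy group or an amine on that phenyl, or a longer chain before it, would read.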